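Removing a ring methyl: what it costs in lipophilicity

The compounds below may be only part of what the source reports. "The series", "measured", "known", "first", "only" and "open" are said of these compounds alone.

Measured so far:
compound 1 `Cc1cccc(Cl)c1OCC(O)CO`, 1.97
compound 2 `OCC(O)COc1ccccc1Cl`, 1.29
compound 3 `Cc1cc(OCC(C)O)cc(C)c1Cl`, 3.18

In a physicochemical assay for lipophilicity, measured as octanol-water partition (a higher number here means a more lipophilic compound, a lower number a more polar compound), compound 3 stands highest of the three. The step from compound 1 to compound 2, (hydrogen in place of methyl on an aromatic carbon), gave a number 0.68 log units lower from compound 1 to compound 2 (beyond the scatter). Compound 4 `Cc1cc(OCC(C)O)ccc1Cl`, not yet measured, carries the same kind of change on the core of compound 3: hydrogen in place of methyl on an aromatic carbon. The surroundings differ: in compound 1 the methyl sits ortho to a group of 6 heavy atoms and meta to a chloro group, in compound 3 ortho to a chloro group and meta to a methyl group. The difference between the two cores is not broken down here. Resting on the step of a number 0.68 log units lower from compound 1 to compound 2 (beyond the scatter), compound 4 is expected to show a similar drop, a number 0.58 log units lower from compound 3 to compound 4 (beyond the scatter). The estimate for compound 4 in this assay is 2.6, expected between 2.3 and 2.95.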

Compound 4, partition coefficient: 2.67
Beside the measured number, compound 4's estimate is 0.07 log units below it; the range from low to high includes it.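

Replacing methyl with hydrogen on an aromatic carbon gave, in this assay, a number 0.51 log units lower from compound 3 to compound 4 (beyond the scatter), in the same direction as a number 0.68 log units lower from compound 1 to compound 2 (beyond the scatter) on the other core. In these two pairs the change therefore carried from one core to another, even though the methyl sits in different surroundings, but two pairs do not make a rule for other cores or other ring positions. Nothing given here accounts for the drop on either core.

The compounds shown leave open whether the step would hold on a core carrying an amine or a carboxylic acid. They also leave open what would happen if a longer chain, rather than methyl, gave way to hydrogen.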